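This account rests on a few compounds, and the source may have more. Where it says the series, first, only, none or still open, it means among the compounds named here.

Measured compounds in a functional assay on the whole organism with Mus musculus as the target; on this read-out higher numbers stand for an effect only at larger amounts of compound and lower numbers for an effect already at smaller amounts:
compound 1 `COc1cc2c(cc1OC)C(c1ccc([N+](=O)[O-])cc1)=NN=C(S)C2` — 93.4 umol/kg
compound 2 `COc1cc2c(cc1OC)C(c1ccc(Cl)cc1)=NN=C(S)C2` — 82.4 umol/kg
compound 3 `COc1cc2c(cc1OC)C(c1ccc([N+](=O)[O-])cc1)=NNC(=O)C2` — only a limit of the assay, > 120 umol/kg

Between compound 1 and compound 2 the change is chloro in place of nitro on an aromatic carbon; it gave a 1.1-fold lower number from compound 1 to compound 2 (0.05 log units; within the scatter). Compound 3 sits on a different core, and the difference between the two cores is not broken down here. For compound 3 the read-out is a limit and not a number, (the limit of > 120 umol/kg in this assay, at which 1 of the 3 values shown sits).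

Compound 4 `COc1cc2c(cc1OC)C(c1ccc(Cl)cc1)=NNC(=O)C2` is not yet measured in this assay. It differs from compound 3 by chloro in place of nitro on an aromatic carbon, the same change made from compound 1 to compound 2. Because that earlier step was a 1.1-fold lower number from compound 1 to compound 2 (0.05 log units; within the scatter), the step for compound 4 is expected to be small as well, about a step that the limit leaves unreadable from compound 3 to compound 4. Compound 4 is therefore estimated at 140 umol/kg, with a real chance that only a limit is reported again.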

Compound 4, dose for half-maximal effect: 102 umol/kg
Compound 4: middle estimate off by 1.4-fold (0.14 log units), on the high side, within the range that was stated.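

In this assay, chloro in place of nitro on an aromatic carbon gave an at least 1.1-fold lower number from compound 3 to compound 4 (0.07 log units; that floor lies within the scatter), which fixes only a floor and not the true size of the step. For compound 3, > 120 umol/kg is a limit of the assay and not a number. The pair therefore neither confirms nor rules out that the change carries from one core to the other with the same size: the same change on two cores in this assay, a 1.1-fold lower number (0.05 log units; within the scatter) from compound 1 to compound 2 and an at least 1.1-fold lower number (0.07 log units; that floor lies within the scatter) from compound 3 to compound 4; the limit leaves it open whether they differ

Going by these compounds, only nitro and chloro appear at this aromatic carbon, so the effect of an amine or a carboxylic acid there stays open on both cores in this assay. A numerical value on the core of compound 3 with nitro would also be needed to read this step in full.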